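Phenyl in place of 2-phenylethenyl: an expected cytotoxicity step

The source may report more compounds than this note shows. Statements on the series, on what has been measured and on what is new or still open speak of the compounds shown alone.

Measured in a functional assay on SMMC-7721 cells (Homo sapiens) for cytotoxicity, read by MTT assay, with a stated time of 72 h; a higher number here means a weaker inhibitor, a lower number a stronger inhibitor:
compound 1 `COc1cccc(C=C2C(=O)N(c3ccc(Cl)cc3)N(c3ccc(Cl)cc3)C2=O)c1O`: 64900 nM
compound 2 `O=C1C(=C/C=C/c2ccccc2)C(=O)N(c2ccc(Cl)cc2)N1c1ccc(Cl)cc1`: 10100 nM

Of these two numbers, compound 2 holds the lower, and a 6.4-fold lower number from compound 1 to compound 2 (0.81 log units; beyond the scatter) separates the pair. The next case is compound 3 `O=C1C(=Cc2ccccc2)C(=O)N(c2ccc(Cl)cc2)N1c1ccc(Cl)cc1`, described by phenyl in place of 2-phenylethenyl on a double-bonded chain carbon bound to a double-bonded ring carbon. Within the data shown here, only one measured step touches this place, the one just given, where compound 1 carries 2-hydroxy-3-methoxyphenyl. Among the measured compounds shown here, that single modest step is thin evidence, and no measured compound has the plain phenyl. Losing 2-phenylethenyl is therefore expected to move the number in this assay upward, towards compound 1 at 64900 nM, but not all the way. The expected change is a 2.2-fold higher number from compound 2 to compound 3 (0.34 log units; beyond the scatter). For compound 3 the estimated value is 22000 nM, with an expected range from 8000 nM to 60000 nM.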

Compound 3, half-maximal inhibitory concentration: 26200 nM
For compound 3 the middle estimate is 1.2-fold (0.08 log units) below the measured one; measured number inside the range.
By their numbers in this assay, from the lowest: compound 2; then compound 3; then compound 1.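

Compound 3 splits the earlier step into two parts at this position. In this assay, removing the 2-phenylethenyl group in favour of phenyl gives a 2.6-fold higher number from compound 2 to compound 3 (0.41 log units; beyond the scatter), so the extra double bond outside the aromatic ring goes with the lower number in this pair. Placing the plain phenyl against 2-hydroxy-3-methoxyphenyl gives a 2.5-fold lower number from compound 1 to compound 3 (0.39 log units; beyond the scatter), which shows that the gain from compound 1 does not depend on the 2-phenylethenyl group alone, and nothing available explains either step.

The compounds shown leave open whether the hydroxy or the methoxy group on the ring of compound 1 goes with its higher number, since the two appear only together. They also leave open how a longer chain carrying the phenyl, or an amine on that ring, would read in this assay.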